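The source may hold more compounds than are shown below. What is called first, only, known or untested is meant among the compounds shown, and "the series" means these compounds.

Working notes on the maleimide chalcone series.

The shared core is that of compound 1, `O=C(/C=C/c1ccc(Cl)cc1)c1ccc(N2C(=O)C=CC2=O)cc1`. In a functional assay on MOLT-4 cells (Homo sapiens) for cytotoxicity (a higher number here means a weaker inhibitor, a lower number a stronger inhibitor), compound 1 gives 7500 nM. Going by the values given here, the only other measured member, compound 2, `COc1ccc(/C=C/C(=O)c2ccc(N3C(=O)C=CC3=O)cc2)cc1OC`, carries two methoxy groups on the cinnamoyl ring; in this assay compound 2 gives 202000 nM. Compound 1 therefore holds the lower of the two numbers, and the gap to compound 2 lies beyond the usual scatter of repeated measurements. Among the compounds with values here, no step between measured compounds that differ in a single place is available, so no direct comparison of this kind can be drawn.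

Compound 3, `O=C(O)c1ccc(/C=C/C(=O)c2ccc(N3C(=O)C=CC3=O)cc2)cc1`, is still to be measured. It differs from compound 1 as follows: carboxy in place of chloro on an aromatic carbon. Within the data shown here, no measured pair mirrors this change, so the expectation rests on compound 1 alone and on the weaker reading of compound 2. A shift in the direction of a higher number is expected, of modest size, since the change from compound 1 to compound 3 is estimated at a 3.3-fold higher number from compound 1 to compound 3 (0.52 log units; beyond the scatter). For compound 3 in this assay the estimated value is 25000 nM, with a range from 5000 nM to 150000 nM.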

Compound 3, half-maximal inhibitory concentration: 178000 nM
Estimate against measurement, compound 3: 7.1-fold (0.85 log units) below; measured number outside the range, above it.
By their numbers in this assay, from the lowest: compound 1; then compounds 3 and 2 (each within the scatter of the next).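

In this assay, going by these compounds alone, carboxy in place of chloro on this aromatic carbon, para to a large group, gives a 24-fold higher number from compound 1 to compound 3 (1.38 log units; beyond the scatter) and so provides the first single-place comparison. The step is large and lies well beyond the scatter, which shows that the group at this position can by itself move the number substantially, with the shared core and the other ring left unchanged. No measurement available here accounts for the size of this step or for its direction.

The step has only two ends, so the compounds shown leave open whether the higher number of compound 3 reflects the entry of carboxy, the loss of chloro, or both, and how a plain hydrogen at this position would read. A methyl ester or a primary amide in the same place would show whether the change follows from the free carboxylic acid or extends to other carbonyl groups, while fluoro or bromo would show how closely the number of compound 1 depends on chloro itself.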